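Swapping the amino-acid tail on a benzothiazole-linked hydrazide

The source may hold more compounds than are shown below. What is called first, only, known or untested is meant among the compounds shown, and "the series" means these compounds.

Measured compounds:
compound 1, `COc1cc(-c2nc3ccccc3s2)ccc1OCC(=O)NNC(=O)CN[C@@H](CS(=O)(=O)O)C(=O)O`: 1870 nM
compound 2, `COc1cc(-c2nc3ccccc3s2)ccc1OCC(=O)NNC(=O)CN[C@@H](CCSC)C(=O)O`: 1950 nM
compound 3, `CCOC(=O)[C@H](CCCNC(=N)NCC(=O)NNC(=O)COc1ccc(-c2nc3ccccc3s2)cc1OC)N[N+](=O)[O-]`: 1950 nM

These three share one core and differ only in the amino-acid-derived tail. In a functional assay on MCF7 cells (Homo sapiens) for inhibition, read by MTT assay, with a stated time of 3 days (a lower number here means a stronger inhibitor, a higher number a weaker inhibitor), compound 2 gives 1950 nM, level with compound 3 at the digits shown, and together they give the highest of the three numbers, though none of the three separates from another beyond the scatter. Among the measured compounds shown here, the only single-point step, a 1.0-fold higher number from compound 1 to compound 2 (0.02 log units; within the scatter), is within the scatter.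

Compound 4, `CCOC(=O)[C@@H]1CCCN1CC(=O)NNC(=O)COc1ccc(-c2nc3ccccc3s2)cc1OC`, is not yet measured. It differs from compound 2 as follows: 2-(ethoxycarbonyl)pyrrolidin-1-yl in place of (1-carboxy-3-(methylsulfanyl)propyl)amino on a saturated chain carbon bound to a carbonyl carbon.

The step from compound 1 to compound 2 is the only measured one at this region, and it was flat. Compound 3 carries yet another tail and sits at the same level. So the expected step of a 1.0-fold higher number from compound 2 to compound 4 (0.01 log units; within the scatter) is none beyond the scatter. For compound 4 the estimate is 2000 nM, within 800 nM to 5000 nM.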

Compound 4, half-maximal inhibitory concentration: 770 nM
Compound 4: the middle estimate sits 2.6-fold (0.41 log units) above what was measured; the whole stated range lies above it.
By their numbers in this assay, from the lowest: compound 4; then compounds 1, 2 and 3 (each within the scatter of the next).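

In this assay this position is not flat after all: the step of a 2.5-fold lower number from compound 2 to compound 4 (0.40 log units; beyond the scatter) and the step of a 2.4-fold lower number from compound 1 to compound 4 (0.39 log units; beyond the scatter) both lie beyond the scatter, unlike the earlier change of tail. Compared with the group it replaces in compound 2, 2-(ethoxycarbonyl)pyrrolidin-1-yl brings a five-membered non-aromatic ring and has no hydrogen-bond donors. No measurement given here explains this step.

Still open, from the compounds shown here alone, is whether the step goes with the ring or with the ethyl ester. A pyrrolidine carrying a free carboxylic acid would separate the two.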